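Swapping a Benzyl Imine for a Butyl Imine

The compounds below may be only part of what the source reports. "The series", "measured", "known", "first", "only" and "open" are said of these compounds alone.

Compound 1 `O=c1[nH]c2ccccc2cc1/C=N/Cc1ccccc1` is measured in a functional assay, read by spectrophotometry, with a stated time of 3 min (on this read-out higher numbers stand for weaker inhibition and lower numbers for stronger inhibition), where compound 1 gives 368000 nM. Two other compounds sharing the same core are also measured. Compound 2 `Cc1ccc2[nH]c(=O)c(/C=N/Nc3ccc([N+](=O)[O-])cc3[N+](=O)[O-])cc2c1` gives 144000 nM, and compound 3 `Cc1ccc2[nH]c(=O)c(/C=N/Nc3ccccc3)cc2c1` gives 8470 nM. Of the three numbers, compound 1 stands highest, which on this read-out means it is the weakest inhibitor of the set; compound 2 is nearest to it, and compound 3 is furthest away, with a far lower number.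

Compound 4 `CCCC/N=C/c1cc2ccccc2[nH]c1=O` has not yet been measured. It differs from compound 1 in one place: propyl in place of phenyl on a saturated chain carbon bound to a double-bonded nitrogen. The chain that enters is propyl, the ring that leaves is phenyl, and the exchange takes place on a saturated chain carbon bound to a double-bonded nitrogen.

Going by the values given here, no pair among the measured compounds shows this kind of exchange, so there is no measured step to lean on. The expectation is a small step from compound 1 toward a higher number, or none beyond the scatter, as a 1.4-fold higher number from compound 1 to compound 4 (0.13 log units; within the scatter). Compound 4 is therefore estimated at 500000 nM, within a range from 200000 nM to 1200000 nM.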

Compound 4, half-maximal inhibitory concentration: 1810000 nM
Estimate against measurement, compound 4: 3.6-fold (0.56 log units) below; measured number above the stated range.
By their numbers in this assay, from the lowest: compound 3; then compound 2; then compound 1; then compound 4.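

In this assay, propyl in place of phenyl on a saturated chain carbon bound to a double-bonded nitrogen gives a 4.9-fold higher number from compound 1 to compound 4 (0.69 log units; beyond the scatter), which means weaker inhibition. Going by these compounds alone, this is the first direct reading of this position, since compound 2 and compound 3 each differ from compound 1 in more than one place and could not show what this group contributes. Nothing measured here says why the number rises.

Going by these compounds, it remains open whether the loss of the ring itself matters or simply the change in the group's size. A cyclohexyl ring or a longer chain at the same place could help separate those two readings, while an amine on the chain would test a different kind of group there.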